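Hydroxamic and aminophenyl amide caps on a shared core

The source may report more compounds than this note shows. Statements on the series, on what has been measured and on what is new or still open speak of the compounds shown alone.

Measured compounds in a functional assay on MV4-11 cells (Homo sapiens) for antiproliferative activity, read by CCK-8 assay, with a stated time of 72 h; a higher number here means a weaker inhibitor, a lower number a stronger inhibitor:
compound 1, `CC(C)Oc1ccc(C(C)(C)O)cc1-c1cn(C)c(=O)c2[nH]c(C(=O)NCc3ccc(C(=O)NO)cc3)cc12`, 350 nM
compound 2, `Cn1cc(-c2ccccc2Oc2ccccc2)c2cc(C(=O)NCCCCC(=O)Nc3ccccc3N)[nH]c2c1=O`, 240 nM
compound 3, `Cn1cc(-c2cccc(Cl)c2)c2cc(C(=O)NCc3ccc(C(=O)Nc4ccccc4N)cc3)[nH]c2c1=O`, 190 nM

All three share one core and differ in the linker from the carboxamide and in the group that closes it. Compound 1 carries a hydroxycarbamoyl cap on a benzyl linker, compound 3 a (2-aminophenyl)carbamoyl cap on the same benzyl linker, and compound 2 the (2-aminophenyl)carbamoyl cap on a five-carbon chain. In this assay the number for compound 2 lies close to those of compounds 1 and 3; the gap to either one falls within the usual scatter, so no order among the three can be read from these numbers.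

Compound 4, `Cn1cc(-c2ccccc2Oc2ccccc2)c2cc(C(=O)NCCCCC(=O)NO)[nH]c2c1=O`, is not yet measured. It keeps the five-carbon chain of compound 2 and changes the cap: hydroxy in place of 2-aminophenyl on an amide-type nitrogen. The same exchange of cap, on the benzyl linker, separates compound 3 from compound 1, and there the two values stay within the scatter. On that basis the expected step from compound 2 to compound 4 is small, none beyond the scatter, and the step of a 1.3-fold higher number from compound 2 to compound 4 (0.10 log units; within the scatter) is estimated accordingly. For compound 4 the expected value is 300 nM, with a range from 120 nM to 800 nM.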

Compound 4, half-maximal inhibitory concentration: 180 nM
Estimate against measurement, compound 4: 1.7-fold (0.22 log units) above; low and high end bracket the measured number.
By their numbers in this assay, from the lowest: compounds 4, 3, 2 and 1 (each within the scatter of the next).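

In this assay, within the data shown here, this pair gives the first reading of the cap exchange with everything else held fixed: hydroxy in place of 2-aminophenyl on an amide-type nitrogen, on the five-carbon chain, gives a 1.3-fold lower number from compound 2 to compound 4 (0.12 log units; within the scatter), so the two caps cannot be told apart at this position. The six-membered aromatic ring of carbon only leaves with the 2-aminophenyl group, and on this chain that difference does not register beyond the scatter of this read-out. No other measurement accompanies the step, and nothing here accounts for its size.

On these data alone, this is a single pair on a single chain, so it remains open whether the exchange stays as small on a longer chain or on a benzyl linker carrying the same remaining structure as compound 4. Among these compounds, it is equally open whether a carboxylic acid or a primary amide in the place of the hydroxycarbamoyl group would also leave the number within the scatter, or would be the first change at this position to move it beyond.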